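The compounds below may be only part of what the source reports. "The series", "measured", "known", "first", "only" and "open" are said of these compounds alone.

Working notes on the arylsulfanyl series

The three measured compounds share one core and differ only in the aryl group attached to the sulfur. Compound 1 `COc1ccc(SCc2ccc(/C=C/C(=O)Nc3ccccc3N)cc2)cc1OC` gives 46.4% in a functional assay on A-375 cells (Homo sapiens) for inhibition, read by CCK-8 assay, with a stated time of 72 h, tested at 8 uM; on this read-out higher numbers stand for more inhibition of growth at the one concentration tested and lower numbers for less inhibition of growth. Compound 2 `Nc1ccccc1NC(=O)/C=C/c1ccc(CSc2ccc(F)cc2)cc1` gives 24.6% in this assay. Compound 3 `Nc1ccccc1NC(=O)/C=C/c1ccc(CSc2ccc(Cl)cc2)cc1` gives 48.2% in this assay.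

Compound 3 sits at the top of the three numbers, but the gap a number 1.8 percentage points higher from compound 1 to compound 3 (within the scatter) lies within the scatter, so compound 1 and compound 3 are not told apart. The gaps to compound 2 are different in kind: a number 21.8 percentage points lower from compound 1 to compound 2 (beyond the scatter), and a number 23.6 percentage points higher from compound 2 to compound 3 (beyond the scatter), both beyond the scatter.

Compound 4 `Cc1cc(C)cc(SCc2ccc(/C=C/C(=O)Nc3ccccc3N)cc2)c1` is not yet measured. Its change from compound 3 is 3,5-dimethylphenyl in place of 4-chlorophenyl on a sulfur. For the measured compounds named here, no measured step brings in a 3,5-dimethylphenyl group, so only the three aryl swaps on the sulfur bear on it: one swap left the number where it was, two moved it modestly. The aryl group on the sulfur can thus shift the read-out modestly or not at all, and no direction can be read for this particular pair. The expected step is a number 6.2 percentage points lower from compound 3 to compound 4 (within the scatter), with a range wide enough to hold a modest move either way.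

Compound 4 is estimated at 42%, between 22% and 60%.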

Compound 4, percent growth inhibition at one concentration: 2.49%
Compound 4: middle estimate off by 39.5 percentage points, on the high side, outside the stated range (below it).
By their numbers in this assay, from the lowest: compound 4; then compound 2; then compounds 1 and 3 (each within the scatter of the next).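

The 3,5-dimethylphenyl group gives the first large moves at this sulfur: a number 45.7 percentage points lower from compound 3 to compound 4 (beyond the scatter) and a number 43.9 percentage points lower from compound 1 to compound 4 (beyond the scatter) both exceed anything the earlier aryl swaps produced, so the group on the sulfur can do far more than shift the read-out modestly. Even against the lowest of the earlier compounds, the change is clear, with a number 22.1 percentage points lower from compound 2 to compound 4 (beyond the scatter) and compound 4 at 2.49% in this assay as the lowest of the four, leaving little growth inhibition at the one concentration tested. No supporting data bear on why this swap has such a large effect.

The compounds shown do not separate the effect of having two methyl groups from the effect of where they sit on the ring, nor show whether methyl itself is the deciding feature. A 4-methylphenyl, a 3,5-dichlorophenyl or an unsubstituted phenyl group on the sulfur would help separate these readings, and the series gives no read-out at other concentrations to show how compound 4 behaves beyond this single test.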